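Lengthening the Isothiocyanate Chain Toward Compound 4

The source may report more compounds than this note shows. Statements on the series, on what has been measured and on what is new or still open speak of the compounds shown alone.

Compound 1 `CN(C)C(=O)c1cc2cnc(Nc3ccc(S(=O)(=O)NCCCN=C=S)cc3)nc2n1C1CCCC1` gives 72.8% in a functional assay on NCI-H1299 cells (Homo sapiens) for inhibition, read by CCK-8 assay, with a stated time of 72 h, tested at 10 uM; on this read-out higher numbers stand for a stronger effect at the one concentration tested and lower numbers for a weaker effect.
Compound 2 `CN(C)C(=O)c1cc2cnc(Nc3ccc(S(=O)(=O)NCCCCCN=C=S)cc3)nc2n1C1CCCC1` gives 83.4% in this assay.
Compound 3 `CN(C)C(=O)c1cc2cnc(Nc3ccc(S(=O)(=O)NCCCCCCN=C=S)cc3)nc2n1C1CCCC1` gives 70.6% in this assay.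

Compound 2 stands highest of the three, with both other compounds lower by steps beyond the scatter. Compound 4 `CN(C)C(=O)c1cc2cnc(Nc3ccc(S(=O)(=O)NCCCCCCCN=C=S)cc3)nc2n1C1CCCC1` differs from compound 2 by a group of 5 heavy atoms (3 carbon, 1 nitrogen, 1 sulfur; no ring) in place of a group of 3 heavy atoms (1 carbon, 1 nitrogen, 1 sulfur; no ring), on a saturated chain carbon, five bonds along the chain from a sulfonamide nitrogen. For the measured compounds named here, two measured steps bear on this: a number 10.6 percentage points higher from compound 1 to compound 2 (beyond the scatter), and a number 12.8 percentage points lower from compound 2 to compound 3 (beyond the scatter). The first lengthening raised the read-out, the next lowered it, and the net a number 2.2 percentage points lower from compound 1 to compound 3 (within the scatter). A further lengthening past compound 2 is therefore expected to give a modest drop rather than a gain, so compound 4 is estimated to show a number 13.4 percentage points lower from compound 2 to compound 4 (beyond the scatter). Compound 4 is expected to give 70% in this assay, within 55% to 83%.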

Compound 4, a percentage reported as inhibition, at one concentration (the size of the read-out at that concentration, not a potency): 83%
For compound 4 the middle estimate is 13 percentage points below the measured one; the range from low to high includes it.
By their numbers in this assay, from the lowest: compounds 3 and 1 (each within the scatter of the next); then compounds 4 and 2 (each within the scatter of the next).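

In this assay the drop at compound 3 does not continue as the chain grows: the steps read a number 12.4 percentage points higher from compound 3 to compound 4 (beyond the scatter) and a number 10.2 percentage points higher from compound 1 to compound 4 (beyond the scatter) while a number 0.4 percentage points lower from compound 2 to compound 4 (within the scatter) stands level. The read-out therefore follows no steady trend with chain length at this position, and compound 3 goes against any pattern of the longer chains doing better. Nothing measured here explains this dip and recovery. Going by these compounds, whether a still longer chain would hold this level stays open, as does what an amine in place of the isothiocyanate would give.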